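Adding a Hydroxy Group to Compound 2

This account rests on a few compounds, and the source may have more. Where it says the series, first, only, none or still open, it means among the compounds named here.

In a functional assay on HeLa cells (Homo sapiens) for inhibition, read by trypan blue exclusion, with a stated time of 72 h (on this read-out lower numbers stand for stronger inhibition of growth and higher numbers for weaker inhibition of growth), compound 1 (`CC/C(=C(\c1ccccc1)c1ccc(NC(=O)C(C)C)cc1)c1ccccc1`) gives > 30000 nM as a limit of the assay, not a number. Going by the values given here, compound 2 (`CC/C(=C(\c1ccccc1)c1ccc(NC(=O)C(C)C)cc1)c1ccc(Cl)cc1Cl`) gives 3300 nM as the only actual number so far. Compound 3 (`CC/C(=C(\c1ccc(O)cc1)c1ccc(NC(=O)C(C)C)cc1)c1ccc(Cl)cc1Cl`) differs from it by hydroxy in place of hydrogen on an aromatic carbon in the change from phenyl to 4-hydroxyphenyl. Among the compounds with values here, the one measured step of an at least 9.0-fold lower number from compound 1 to compound 2 (0.95 log units; beyond the scatter) changed a different group, so it offers only a loose guide. The estimated step of a 2.2-fold lower number from compound 2 to compound 3 (0.34 log units; beyond the scatter) is expected to be smaller and again toward stronger inhibition of growth. For compound 3 the expected value is 1500 nM with an estimated range of 400 nM to 8000 nM for now.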

Compound 3, concentration for 50% growth inhibition: 8700 nM
Beside the measured number, compound 3's estimate is 5.8-fold (0.76 log units) below it, and the stated range ends below it.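

In this assay, hydroxy in place of hydrogen on an aromatic carbon, para to a large group, gives a 2.6-fold higher number from compound 2 to compound 3 (0.42 log units; beyond the scatter) and so weakens inhibition of growth modestly. Going by these compounds alone, the earlier step changed a different group, so this is the first reading at this position, and it shows that adding a single oxygen here is not tolerated without loss. No measurement shown bears on why inhibition weakens with this change.

As far as these compounds go, whether a methoxy group, an amine or a fluorine at this same position would also weaken inhibition stays open. So does whether hydroxy would have the same effect without the two chlorines of compound 2.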